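Shortening the Ester Chain to a Free Acid

This account rests on a few compounds, and the source may have more. Where it says the series, first, only, none or still open, it means among the compounds named here.

Measured so far:
compound 1, `CCCCC1([C@@H](O)/C=C/C2[C@H](O)CC(=O)[C@@H]2CCCCCCC(=O)O)CCC1`, 0.017 mg/kg
compound 2, `CCCCC1([C@H](O)/C=C/C2CCC(=O)[C@@H]2CCCCCCCCC(=O)OCC)CCC1`, 6.21 mg/kg
compound 3, `CCCC1([C@@H](O)/C=C/C2[C@H](O)CC(=O)[C@@H]2C/C=C\CCCC(=O)O)CCC1`, 0.0467 mg/kg

In a functional assay on the whole organism (strain Hartley) for inhibition, with Cavia porcellus as the target, with stated times of 15 min and 2 min (on this read-out higher numbers stand for an effect only at larger amounts of compound and lower numbers for an effect already at smaller amounts), compound 2 stands at the high end of the three numbers: its value is the highest of the set, and both compound 3 and compound 1 sit far lower, beyond the usual scatter in each case. Compound 3 is the nearer of the two, compound 1 the furthest away.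

Compound 4, `CCCCC1([C@H](O)/C=C/C2CCC(=O)[C@@H]2CCCCCCC(=O)O)CCC1`, has not yet been measured in this assay. It differs from compound 2 in one place, (carboxy in place of 2-(ethoxycarbonyl)ethyl on a saturated chain carbon, six bonds along the chain from a saturated ring carbon). Within the data shown here, nothing else in the molecule is altered, and no directly comparable pair among the measured compounds carries this same change, so its size cannot be read from a measured step.

The expectation therefore rests on the surrounding numbers. Compound 4 shares the carboxy terminus and the chain length of compound 1 and compound 3, both of which give markedly lower values than compound 2, but it lacks the ring hydroxyl that both of them carry. A step well beyond the scatter, toward a lower number, is expected, roughly a 31-fold lower number from compound 2 to compound 4 (1.49 log units; beyond the scatter). Compound 4 is estimated at 0.2 mg/kg, with a plausible range from 0.03 mg/kg to 1.5 mg/kg.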

Compound 4, dose for half-maximal effect: 0.0024 mg/kg
For compound 4 the middle estimate is 83-fold (1.92 log units) above the measured one, and the stated range ends above it.
By their numbers in this assay, from the lowest: compound 4; then compound 1; then compound 3; then compound 2.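

In this assay the replacement of 2-(ethoxycarbonyl)ethyl by carboxy, on a saturated chain carbon, six bonds along the chain from a saturated ring carbon, gives a 2600-fold lower number from compound 2 to compound 4 (3.41 log units; beyond the scatter) and is large and beyond the scatter. Among these compounds, the earlier compounds offered no pair differing in one place, so this is the first step that isolates this position, and it shows that the end of this chain alone, with the rest of the molecule unchanged, can move the dose needed for half-maximal effect by a very wide margin. Nothing available explains why the change has so large an effect in this whole-organism read-out.

The step joins two alterations, the loss of the ethyl ester and the shortening of the chain, and the compounds shown cannot separate them, since neither an ethyl ester on the shorter chain of compound 4 nor a carboxylic acid on the longer chain of compound 2 stands among them. Also open, as far as these compounds go, is how other chain ends, such as a methyl ester or a primary amide, would behave at this position.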